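The source may hold more compounds than are shown below. What is called first, only, known or untested is meant among the compounds shown, and "the series" means these compounds.

The measured compounds:
compound 1, `O=C1C(Nc2ccccc2)=CC(=O)c2c1nc1n2[C@H]2OC[C@@H](O)[C@H]2OC1`: > 8000 nM
compound 2, `O=C1C=C(Nc2ccccc2F)C(=O)c2c1nc1n2[C@H]2OC[C@@H](O)[C@H]2OC1`: 5120 nM
compound 3, `O=C1C(N2CCCCC2)=CC(=O)c2c1nc1n2[C@H]2OC[C@@H](O)[C@H]2OC1`: > 16000 nM

All three share one core and differ only in the group on a double-bonded ring carbon. Among the compounds with values here, in a functional assay on HeLa cells (Homo sapiens) for inhibition, read by sulforhodamine B assay (on this read-out higher numbers stand for weaker inhibition and lower numbers for stronger inhibition), compound 2 gives 5120 nM, and this is the only actual number among the three. Compound 1, which carries a plain anilino group there, reaches only a limit of this assay, > 8000 nM. Compound 3, with piperidin-1-yl in place of anilino, likewise stops at a limit, > 16000 nM. Within the data shown here, the one step between measured compounds, a step that the two limits leave unreadable from compound 1 to compound 3, cannot be read in size: both of its ends are limits, the limit of > 8000 nM in this assay, at which 1 of the 3 values shown sits, and (the limit of > 16000 nM in this assay, at which 1 of the 3 values shown sits).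

Compound 4, `COc1ccc(NC2=CC(=O)c3nc4n(c3C2=O)[C@H]2OC[C@@H](O)[C@H]2OC4)cc1`, is not yet measured. It differs from compound 2 in one place: 4-methoxyphenyl in place of 2-fluorophenyl on an amine nitrogen. The 2-fluorophenyl leaves and a 4-methoxyphenyl enters, on an amine nitrogen whose other neighbour is a double-bonded ring carbon. Among the measured compounds shown here, no measured step alters the ring on this amine nitrogen; the only recorded step swaps the whole anilino group for piperidin-1-yl, and its size is unreadable. The expectation for compound 4 rests on compound 2 alone, with an expected step of a 1.2-fold higher number from compound 2 to compound 4 (0.07 log units; within the scatter) that should stay within the usual scatter. Compound 4 is estimated at 6000 nM in this assay, with a range from 2500 nM to 16000 nM, and a real chance that only a limit is reported.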

Compound 4, half-maximal inhibitory concentration: 4780 nM
For compound 4 the middle estimate is 1.3-fold (0.10 log units) above the measured one; the measured number falls inside the stated range.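

Within the data shown here, this is the first readable step that alters the ring on the amine nitrogen: in this assay, 4-methoxyphenyl in place of 2-fluorophenyl gives a 1.1-fold lower number from compound 2 to compound 4 (0.03 log units; within the scatter). Two phenyl rings bearing different groups therefore read alike at this position, even though the change adds an oxygen and a hydrogen-bond acceptor by the count of the two groups, and the series now has two actual numbers rather than one. Nothing measured here explains why these two rings read alike.

The change swaps both the group and its place on the phenyl ring, so a pair such as 4-fluorophenyl and 2-methoxyphenyl would be needed to tell the two apart, and a single pair says nothing about the phenyl ring in general. Going by these compounds, it also remains open whether a carboxylic acid or a dimethylamino group on that ring, or a benzyl group or a butyl chain on the amine nitrogen in its place, would move the number beyond the usual scatter.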